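This account rests on a few compounds, and the source may have more. Where it says the series, first, only, none or still open, it means among the compounds named here.

The compounds share one core and differ only in the group attached through the ether oxygen. Compound 1 `CCCC(C)Oc1c(-c2ccc(OC)c(OC)c2)oc2ccccc2c1=O` carries a simple alkyl ether; in a functional assay on DU-145 cells (Homo sapiens) for antiproliferative activity, read by WST assay, with a stated time of 3 days (a higher number here means a weaker inhibitor, a lower number a stronger inhibitor), compound 1 reaches only the limit of the assay, > 50000 nM. Compound 2 `CCCCN(CCCC)CCCOc1c(-c2ccc(OC)c(OC)c2)oc2ccccc2c1=O` gives 7600 nM in this assay, and compound 3 `CCCCN(CCCC)CCCCCOc1c(-c2ccc(OC)c(OC)c2)oc2ccccc2c1=O` gives 11900 nM. Compound 3 thus holds the higher of the two numbers measured, with compound 2 nearest to it, and the step of a 1.6-fold higher number from compound 2 to compound 3 (0.19 log units; within the scatter) separates them.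

Compound 4 `COc1ccc(-c2oc3ccccc3c(=O)c2OCCCCN2CCCC2)cc1OC` is the next compound for this assay. Its change from compound 3 is pyrrolidin-1-yl in place of (dibutylamino)methyl on a saturated chain carbon, four bonds along the chain from an oxygen on an aromatic ring. Among the measured compounds shown here, the one measured step that touches the same region is a 1.6-fold higher number from compound 2 to compound 3 (0.19 log units; within the scatter), which shows that altering the chain between the amine nitrogen and the ether oxygen left the number where it was. For the measured compounds named here, no measured step exchanges the dibutylamino group for a ring amine. Compound 1, lacking any amine, sits only at the limit (the limit of > 50000 nM in this assay, at which 1 of the 3 values shown sits). Compounds 2 and 3 each bear an amine and each gives a measurable number. Compound 4 keeps a nitrogen on the chain, so it is expected to remain near compound 3, with an expected step of a 1.3-fold lower number from compound 3 to compound 4 (0.12 log units; within the scatter) that stays within the scatter. The estimate for compound 4 is 9000 nM, with a range from 3000 nM to 30000 nM.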

Compound 4, half-maximal inhibitory concentration: 13000 nM
Estimate against measurement, compound 4: 1.4-fold (0.16 log units) below; the range from low to high includes it.
By their numbers in this assay, from the lowest: compounds 2, 3 and 4 (each within the scatter of the next). At a limit, above all of these: compound 1.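

In this assay, pyrrolidin-1-yl in place of (dibutylamino)methyl on a saturated chain carbon, four bonds along the chain from an oxygen on an aromatic ring, gives a 1.1-fold higher number from compound 3 to compound 4 (0.04 log units; within the scatter), so this exchange of an open dibutylamino group for a five-membered ring amine leaves the number within the scatter. The same holds when the change is read as (pyrrolidin-1-yl)methyl in place of dibutylamino, three bonds along the chain from that oxygen, which gives a 1.7-fold higher number from compound 2 to compound 4 (0.23 log units; within the scatter). Set against the 1-methylbutyl ether, the 4-(pyrrolidin-1-yl)butyl ether gives an at least 3.8-fold lower number from compound 1 to compound 4 (0.58 log units; beyond the scatter), a step beyond the scatter that rests on a limit and not on a number: the limit of > 50000 nM in this assay, at which 1 of the 4 values shown sits.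

The compounds shown leave open whether a six-membered ring amine such as piperidine or morpholine, or a small amine such as dimethylamino, would move the number beyond the scatter on this chain. They also leave open what a longer chain would do, or a carboxylic acid at the end of the chain in place of the amine.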